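Swapping an amide chain for a halogenated phenyl ring

The source may hold more compounds than are shown below. What is called first, only, known or untested is meant among the compounds shown, and "the series" means these compounds.

Compound 3, `CCOC(=O)C1=Cc2ccccc2OC1(OCc1cn(CC(=O)Nc2ccccc2Br)nn1)C(F)(F)F`, carries a ((2-bromophenyl)carbamoyl)methyl group on an aromatic nitrogen of its five-membered ring. In a functional assay on MCF7 cells (Homo sapiens) for inhibition, read by MTT assay, with a stated time of 24 h (a higher number here means a weaker inhibitor, a lower number a stronger inhibitor), compound 3 gives > 150000 nM, which is a limit of the assay rather than a number. the limit of > 150000 nM in this assay, at which 2 of the 3 values shown sit, holds compound 3 together with compound 2, `CCOC(=O)C1=Cc2ccccc2OC1(OCc1cn(-c2ccccc2)nn1)C(F)(F)F`. In this assay compound 2 gives > 150000 nM, again a limit. For the measured compounds named here, compound 1, `CCOC(=O)C1=Cc2ccccc2OC1(OCc1cn(-c2ccc(F)cc2)nn1)C(F)(F)F`, bears a 4-fluorophenyl group on the same nitrogen, and in this assay compound 1 gives 9100 nM, the only number among the three.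

Compound 4, `CCOC(=O)C1=Cc2ccccc2OC1(OCc1cn(-c2ccc(F)c(Cl)c2)nn1)C(F)(F)F`, is not yet measured. The change from compound 3 is 3-chloro-4-fluorophenyl in place of ((2-bromophenyl)carbamoyl)methyl on an aromatic nitrogen. Going by the values given here, two measured steps bear on it. The step of an at least 16-fold higher number from compound 1 to compound 3 (1.21 log units; beyond the scatter) shows that moving from a 4-fluorophenyl group to the amide chain weakens inhibition strongly, so the reverse direction should recover it. The step that the two limits leave unreadable from compound 2 to compound 3 cannot be sized. The change from a 4-fluorophenyl to a plain phenyl group, an at least 16-fold higher number from compound 1 to compound 2 (1.21 log units; beyond the scatter), shows that a single halogen on this ring can move the number greatly, so the added chloro group brings real uncertainty.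

The step is expected to be an at least 18-fold lower number from compound 3 to compound 4 (1.27 log units; beyond the scatter). Compound 4 is expected to give 8000 nM, within a range from 2000 nM to 60000 nM.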

Compound 4, half-maximal inhibitory concentration: 25300 nM
Compound 4: middle estimate off by 3.2-fold (0.50 log units), on the low side; low and high end bracket the measured number.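

In this assay, a second halogenated phenyl group on the aromatic nitrogen of the five-membered ring also gives a real number rather than a limit, with an at least 5.9-fold lower number from compound 3 to compound 4 (0.77 log units; beyond the scatter) and an at least 5.9-fold lower number from compound 2 to compound 4 (0.77 log units; beyond the scatter), so among these four compounds both phenyl rings that carry fluoro give a number. More halogen on that ring does not bring a lower number, however: adding chloro to the 4-fluorophenyl group gives a 2.8-fold higher number from compound 1 to compound 4 (0.44 log units; beyond the scatter), so the 3-chloro-4-fluorophenyl group is less favourable here than the 4-fluorophenyl group alone. The step between compound 2 and compound 3 still cannot be read, and each of these two compounds remains at a limit of the assay rather than a number: the limit of > 150000 nM in this assay, at which 2 of the 4 values shown sit.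

Going by these compounds, whether fluoro itself is needed on that ring remains open, since nothing here shows if a methoxy group, an amine or a nitrile on the same carbon would also give a number. On these data alone, it is also open whether chloro can replace fluoro outright, as a 4-chlorophenyl group would test, and whether a longer chain between the nitrogen and a 4-fluorophenyl ring would keep the number seen with the directly attached ring.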